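The source may report more compounds than this note shows. Statements on the series, on what has been measured and on what is new or still open speak of the compounds shown alone.

Compound 1 `CC(=O)N1CCC(C[C@@H](c2nc3ccc(C)cc3n2C)N2C(=O)CN(c3ccc(Oc4ccccc4)cc3)C2=O)CC1` gives 17200 nM
Compound 2 `Cc1ccc2nc([C@H](CC3CCN(C(=O)C4CCCC4)CC3)N3C(=O)CN(c4ccc(Oc5ccccc5)cc4)C3=O)n(C)c2c1` gives > 100000 nM as a limit

For the measured compounds named here, in a functional assay on Hep 3B2 cells (Homo sapiens) for cytotoxicity, read by MTT assay (a higher number here means a weaker inhibitor, a lower number a stronger inhibitor), compound 1 gives 17200 nM as the only true number so far. Compound 2 stands at > 100000 nM and that is a limit, not a number.

Compound 3 `CC(=O)N1CCC(C[C@@H](c2nc3ccccc3n2C)N2C(=O)CN(c3ccc(Oc4ccccc4)cc3)C2=O)CC1` differs from compound 1 by one small edit hydrogen in place of methyl on an aromatic carbon with hydrogen in place of methyl on an aromatic carbon. Going by the values given here, the only measured step of an at least 5.8-fold higher number from compound 1 to compound 2 (0.76 log units; beyond the scatter) swaps methyl for cyclopentyl on a carbonyl carbon. That is a different place in the molecule, so it gives little guide to this edit, and no step beyond the scatter is expected in either direction. The estimate therefore starts from compound 1 at 17200 nM as its anchor. For compound 3 the expected value is 20000 nM with an estimated range from 7000 nM to 60000 nM as its limits of expectation. This estimate means an expected 1.2-fold higher number from compound 1 to compound 3 (0.07 log units; within the scatter) in this comparison.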

Compound 3, half-maximal inhibitory concentration: 32100 nM
The estimate for compound 3 lay 1.6-fold (0.21 log units) below the measured number, and the stated range covers the measured number.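

In this assay the change from 1,6-dimethyl-1H-benzimidazol-2-yl to 1-methyl-1H-benzimidazol-2-yl gives a 1.9-fold higher number from compound 1 to compound 3 (0.27 log units; within the scatter) and is the first step shown at this aromatic carbon. This step lies within the usual scatter of repeat measurements. The methyl can be replaced by hydrogen here without a readable change in this cell test. For the compounds shown here, compound 2, with its cyclopentyl on the carbonyl carbon, remains the only compound at a limit rather than a number: the limit of > 100000 nM in this assay, at which 1 of the 3 values shown sits.

From the compounds shown here alone, whether a larger or different group at this aromatic carbon, such as a methoxy group, a chlorine atom or an amine, would move the number beyond the scatter stays open. Also open, going by these compounds, is where an ethyl group on the carbonyl carbon would fall relative to methyl and cyclopentyl.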